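This account rests on a few compounds, and the source may have more. Where it says the series, first, only, none or still open, it means among the compounds named here.

Compound 1 `NCc1cc(Oc2cccc(Oc3ccccc3)c2)nc(C(F)(F)F)c1`: "not determined" (no result reported).
Compound 2 `NCc1cc(Oc2cccc(C(=O)NCCn3cnnn3)c2)nc(C(F)(F)F)c1`: 1990 nM.

In an ADME assay on the whole organism (plasma, Mus musculus) for pharmacokinetics, read by LC-MS, at a dose of 30 mg/kg by the oral route (on this read-out lower numbers stand for lower exposure and higher numbers for higher exposure at the dose given), compound 2 gives 1990 nM, the only number shown in this set; compound 1 has "not determined" (no result reported) there, so compound 2 has nothing to be ranked against. Compound 3 `NCc1cc(Oc2cccc(C(=O)Nc3ccccc3)c2)nc(C(F)(F)F)c1` differs from compound 2 by phenyl in place of 2-(1H-tetrazol-1-yl)ethyl on an amide-type nitrogen. Within the data shown here, with no measured step between two compounds to draw on, the step of a 1.1-fold higher number from compound 2 to compound 3 (0.04 log units; within the scatter) is expected to be small, most likely within the usual scatter. For compound 3 the maximal plasma concentration in this assay is estimated at 2200 nM, with a range from 600 nM to 8000 nM.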

Compound 3, maximal plasma concentration: 860 nM
For compound 3 the middle estimate is 2.6-fold (0.41 log units) above the measured one, within the range that was stated.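

Among these compounds, on the amide-type nitrogen, phenyl in place of 2-(1H-tetrazol-1-yl)ethyl gives a 2.3-fold lower number from compound 2 to compound 3 (0.36 log units; beyond the scatter) in this assay and provides the first measured step at this position. The group on this nitrogen therefore affects the maximal plasma concentration, though only modestly in this one pair.

The change replaces the ring and the ethyl chain together, so it remains open which part accounts for the step. From the compounds shown here alone, it is also open how an amine, a carboxylic acid or a longer chain ending in phenyl would read out at this position. No measurement offered here accounts for the step.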